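The source may hold more compounds than are shown below. What is called first, only, known or untested is meant among the compounds shown, and "the series" means these compounds.

The measured compounds:
Compound 1, `O=C(Nc1cccc(OC(F)(F)F)c1)NC1CCN(C/C2=C/CCCCCC2)CC1`, gives 104 nM in a functional assay on CHO cells for antagonist activity at C-X-C chemokine receptor type 3 (Homo sapiens), read by GTPgammaS binding; on this read-out higher numbers stand for weaker inhibition and lower numbers for stronger inhibition.
Compound 2, `CC1(C)[C@H]2CC=C(CN3CCC(NC(=O)Nc4ccccc4)CC3)[C@@H]1C2`, gives 2000 nM in this assay.
Compound 3, `COc1cccc(NC(=O)NC2CCN(CC3=CC[C@H]4C[C@@H]3C4(C)C)CC2)c1`, gives 429 nM in this assay.

Among these three, compound 3 stands second highest. Its nearest neighbour is compound 1, which shows a lower number; the furthest is compound 2, from which it is separated by a 4.7-fold lower number from compound 2 to compound 3 (0.67 log units; beyond the scatter) when methoxy replaces hydrogen on an aromatic carbon, a modest step. Compound 4, `CC1(C)[C@H]2CC=C(CN3CCC(NC(=O)Nc4cccc(OC(F)(F)F)c4)CC3)[C@@H]1C2`, has not yet been measured. It differs from compound 3 by trifluoromethyl in place of methyl on an oxygen on an aromatic ring. No measured step covers exactly this exchange; the single step shown concerns the arrival of the methoxy itself. Compound 1 carries the trifluoromethoxy group on a different core and shows the lowest number of the three, which gives some ground for expecting a lower number for compound 4, though the change of core clouds that comparison. Compound 4 is therefore estimated at 150 nM, with a range from 50 nM to 450 nM. The expected step is a 2.9-fold lower number from compound 3 to compound 4 (0.46 log units; beyond the scatter).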

Compound 4, inhibition constant: 31 nM
Compound 4: middle estimate off by 4.8-fold (0.68 log units), on the high side, and the stated range ends above it.
By their numbers in this assay, from the lowest: compound 4; then compound 1; then compound 3; then compound 2.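

In this assay, among these compounds, the exchange of methoxy for trifluoromethoxy on the shared core gives a 14-fold lower number from compound 3 to compound 4 (1.14 log units; beyond the scatter), so the group on this oxygen matters far more than the earlier compounds could show. Trifluoromethoxy in place of hydrogen on the aromatic carbon gives a 65-fold lower number from compound 2 to compound 4 (1.81 log units; beyond the scatter), while with trifluoromethoxy held constant, the change of the carbon group on the saturated chain carbon gives a 3.4-fold lower number from compound 1 to compound 4 (0.53 log units; beyond the scatter), so that part of the molecule also counts, though by a smaller step. Nothing measured here bears on the reason for these steps.

From the compounds shown here alone, it remains open whether a chlorine or a nitrile on the same aromatic carbon would match trifluoromethoxy. Going by these compounds, it also remains open whether methoxy on the core of compound 1 would show a step of similar size.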